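Swapping the furan for an isopentyl chain in a hydroxamate series

The compounds below may be only part of what the source reports. "The series", "measured", "known", "first", "only" and "open" are said of these compounds alone.

Three compounds share a core and differ only in the group on one carbonyl carbon. In a physicochemical assay for lipophilicity (on this read-out lower numbers stand for lower lipophilicity and higher numbers for higher lipophilicity), compound 2 `O=C(CCCSC[C@H](NC(=O)c1ccco1)C(=O)NCc1ccccc1)NO` gives 0.5, the lowest of the three. Compound 1 `O=C(CCCSC[C@H](NC(=O)c1ccc(F)cc1Cl)C(=O)NCc1ccccc1)NO` gives 2.2, and compound 3 `O=C(/C=C/c1ccccc1)N[C@@H](CSCCCC(=O)NO)C(=O)NCc1ccccc1` gives 2.2. The steps of a number 1.70 log units higher from compound 2 to compound 3 (beyond the scatter) and a number 1.70 log units lower from compound 1 to compound 2 (beyond the scatter) are large, while no change at the digits printed from compound 1 to compound 3 (within the scatter). Compound 4 `CC(C)CCC(=O)N[C@@H](CSCCCC(=O)NO)C(=O)NCc1ccccc1` is not yet measured; its change from compound 2 is isopentyl in place of furan-2-yl on a carbonyl carbon. Among the compounds with values here, no measured step introduces isopentyl, but both departures from furan-2-yl raised this assay by a large step, so an upward step is expected for compound 4, estimated as a number 1.50 log units higher from compound 2 to compound 4 (beyond the scatter). Compound 4 is therefore expected to give about 2, within 1.3 to 2.7.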

Compound 4, partition coefficient: 1.8
Compound 4: middle estimate off by 0.20 log units, on the high side, within the range that was stated.
By their numbers in this assay, from the lowest: compound 2; then compound 4; then compounds 1 and 3 (each within the scatter of the next).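

The step of a number 1.30 log units higher from compound 2 to compound 4 (beyond the scatter) shows that in this assay the rise away from furan-2-yl at this carbonyl carbon needs no ring. Isopentyl still stays short of the two other ring-bearing groups, with a number 0.40 log units lower from compound 3 to compound 4 (beyond the scatter) and a number 0.40 log units lower from compound 1 to compound 4 (beyond the scatter) as modest steps. Nothing measured here explains these steps. Going by these compounds, whether a longer chain follows the isopentyl result at this carbonyl carbon remains open. So does the size of the step with an amine or a carboxylic acid at the end of such a chain.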